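This account rests on a few compounds, and the source may have more. Where it says the series, first, only, none or still open, it means among the compounds named here.

Of the compounds shown here, three have been measured in a functional assay on HCT-116 cells (Homo sapiens) for positive allosteric modulation, read by MTT assay, with stated times of 24 h and 48 h, tested at 2.5 uM; on this read-out higher numbers stand for more inhibition of growth at the one concentration tested and lower numbers for less inhibition of growth. Compound 1 `CS(=O)(=O)c1ccc(-c2cnc3[nH]cc(-c4nnc(-c5ccncc5)o4)c(=O)c3c2)cc1` gives 29.2%, and compound 3 `CS(=O)(=O)c1ccc(-c2cnc3[nH]cc(-c4nnc(-c5cccnc5)o4)c(=O)c3c2)cc1` gives 28.6%. The two differ by pyridin-4-yl in place of pyridin-3-yl on an aromatic carbon, and that change gave a number 0.6 percentage points higher from compound 3 to compound 1 (within the scatter). Compound 2 `O=c1c(-c2nnc(-c3ccc(F)cc3)o2)c[nH]c2ncc(-c3cccnc3)cc12` gives 20.1%; the difference between its core and the core of compound 3 is not broken down here. Compound 4 `O=c1c(-c2nnc(-c3ccc(F)cc3)o2)c[nH]c2ncc(-c3ccncc3)cc12` is not yet measured and differs from compound 2 by pyridin-4-yl in place of pyridin-3-yl on an aromatic carbon. This is the same kind of change as that from compound 3 to compound 1, but here the place is an aromatic carbon of a six-membered aromatic ring with 1 nitrogen, part of a fused or bridged system of two rings, two atoms from the ring nitrogen, rather than a five-membered aromatic ring with 2 nitrogen and 1 oxygen. Because a number 0.6 percentage points higher from compound 3 to compound 1 (within the scatter) lay within the scatter, the expected step is a number 0.9 percentage points higher from compound 2 to compound 4 (within the scatter). Compound 4 is therefore estimated at 21%, between 10% and 32%.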

Compound 4, percent growth inhibition at one concentration: 19.6%
Compound 4: middle estimate off by 1.4 percentage points, on the high side; measured number inside the range.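

In this assay, pyridin-4-yl in place of pyridin-3-yl gave a number 0.5 percentage points lower from compound 2 to compound 4 (within the scatter). Set beside the earlier case, the change looks the same on both cores: the same change on two cores in this assay, a number 0.6 percentage points higher (within the scatter) from compound 3 to compound 1 and a number 0.5 percentage points lower (within the scatter) from compound 2 to compound 4, 1.1 percentage points apart, within the scatter of two such steps. This shows that the change produced no step beyond the scatter on either core, but it gives no direction for the change and does not show that the same would hold on any other core or at any other concentration.

The compounds shown leave open how the read-out would respond if an aliphatic amine or a carboxylic acid stood at this place instead of pyridin-3-yl or pyridin-4-yl.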